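The source may hold more compounds than are shown below. What is called first, only, known or untested is meant among the compounds shown, and "the series" means these compounds.

Measured compounds (a functional assay on MGC-803 cells (Homo sapiens) for inhibition, read by sulforhodamine B assay; a lower number here means a stronger inhibitor, a higher number a weaker inhibitor):
- compound 1 `Cc1ccc(NC2=CC(=O)c3c(nc4n3[C@H]3OC[C@@H](O)[C@H]3OC4)C2=O)cc1C` gives (1050 nM)
- compound 2 `O=C1C=C(NC2CCCCC2)C(=O)c2c1nc1n2[C@H]2OC[C@@H](O)[C@H]2OC1` gives (> 8000 nM), which is a limit of the assay
- compound 3 `O=C1C=C(Nc2cccc(F)c2)C(=O)c2c1nc1n2[C@H]2OC[C@@H](O)[C@H]2OC1` gives (2180 nM)

Compound 3 (2180 nM) is the higher of the two actual numbers. Compound 1 is its nearest neighbour, lower by a margin just beyond the scatter.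

Compound 4 `Cc1ccc(NC2=CC(=O)c3nc4n(c3C2=O)[C@H]2OC[C@@H](O)[C@H]2OC4)cc1C` is still unmeasured. The change from compound 3 is 3,4-dimethylphenyl in place of 3-fluorophenyl on an amine nitrogen and amounts to 3,4-dimethylphenyl in place of 3-fluorophenyl on an amine nitrogen.

Among the compounds with values here, only one measured step involves this nitrogen substituent: an at least 3.6-fold lower number from compound 2 to compound 3 (0.56 log units; beyond the scatter). It starts from the limit of > 8000 nM in this assay, at which 1 of the 3 values shown sits, and replaces cyclohexyl, whereas the present change exchanges one aromatic ring for another, so it bears on this change only loosely. Within the data shown here, compound 1 also carries a 3,4-dimethylphenyl group and gives (1050 nM), but no measured step links it to compound 3. On that value, a small move toward a lower number is expected, and it may not clear the scatter. The expected step in this assay is modest (a 1.5-fold lower number from compound 3 to compound 4 (0.16 log units; within the scatter)). For compound 4 the estimated value is 1500 nM with an expected range from 550 nM to 4500 nM as a working guess.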

Compound 4, half-maximal inhibitory concentration: 860 nM
Compound 4: middle estimate off by 1.7-fold (0.24 log units), on the high side; measured number inside the range.
By their numbers in this assay, from the lowest: compounds 4 and 1 (each within the scatter of the next); then compound 3. At a limit, above all of these: compound 2.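

In this assay, within the data shown here, exchanging one aromatic ring for another on this amine nitrogen has a measurable effect: 3,4-dimethylphenyl in place of 3-fluorophenyl gives a 2.5-fold lower number from compound 3 to compound 4 (0.40 log units; beyond the scatter), whereas the only earlier step at this nitrogen replaced cyclohexyl and said nothing about the substituents carried by the aromatic ring. Set against cyclohexyl, the 3,4-dimethylphenyl group gives an at least 9.3-fold lower number from compound 2 to compound 4 (0.96 log units; beyond the scatter), so both aromatic rings in this one-place series now read as improvements on the cyclohexyl compound, with no compound shown going against that. Compound 2 stands at a limit, so this comparison fixes only the least possible size of the step: the limit of > 8000 nM in this assay, at which 1 of the 4 values shown sits.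

The step from compound 3 to compound 4 removes the fluorine and adds two methyl groups in one change, so the compounds shown do not separate the share of each, and a phenyl ring carrying a single methyl group would be needed to divide it. Also open, from the compounds shown here alone, is how this nitrogen tolerates a ring bearing a methoxy group, an amine or a carboxylic acid, or an unsubstituted phenyl ring as the plain reference point.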